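The source may report more compounds than this note shows. Statements on the series, on what has been measured and on what is new or still open speak of the compounds shown alone.

In a functional assay on MCF7 cells (Homo sapiens) for antiproliferative activity, read by MTT assay, with stated times of 24 h and 72 h (on this read-out higher numbers stand for weaker inhibition and lower numbers for stronger inhibition), compound 1 `COc1ccc([C@@H]2[C@H](Oc3ccccc3)C(=O)N2c2cc(OC)c(OC)c(OC)c2)cc1[N+](=O)[O-]` gives 69000 nM; compound 2 `COc1cc(N2C(=O)[C@@H](Oc3ccccc3)[C@H]2c2cccc([N+](=O)[O-])c2)cc(OC)c1OC` gives 30000 nM; compound 3 `COc1ccc([C@@H]2[C@H](Oc3ccccc3)C(=O)N2c2cc(OC)c(OC)c(OC)c2)cc1N` gives 12200 nM.

Compound 3 stands lowest of the three, with a 2.5-fold lower number from compound 2 to compound 3 (0.39 log units; beyond the scatter) and a 5.7-fold lower number from compound 1 to compound 3 (0.75 log units; beyond the scatter). Compound 4 `COc1cc(N2C(=O)[C@@H](Oc3ccccc3)[C@H]2c2cccc(N)c2)cc(OC)c1OC` has not been measured; it differs from compound 3 by hydrogen in place of methoxy on an aromatic carbon. The same change separates compound 1 from compound 2, namely (hydrogen in place of methoxy on an aromatic carbon), and there it gave a 2.3-fold lower number from compound 1 to compound 2 (0.36 log units; beyond the scatter). The cores of the two pairs differ by amino in place of nitro on an aromatic carbon. Around the place the surroundings are not identical, ortho to a nitro group in one pair and ortho to an amino group in the other, so the change is the same kind of change rather than the same. Resting on a 2.3-fold lower number from compound 1 to compound 2 (0.36 log units; beyond the scatter), the expected step is a 2.0-fold lower number from compound 3 to compound 4 (0.31 log units; beyond the scatter). Compound 4 is thus expected near 6000 nM, most likely between 2500 nM and 15000 nM.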

Compound 4, half-maximal inhibitory concentration: 17000 nM
The estimate for compound 4 lay 2.8-fold (0.45 log units) below the measured number; measured number above the stated range.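

In this assay, replacing the methoxy group with hydrogen on the core of compound 3 gave a 1.4-fold higher number from compound 3 to compound 4 (0.14 log units; within the scatter), so the change did not carry over in size from the core of compound 1: the same change on two cores in this assay, a 2.3-fold lower number (0.36 log units; beyond the scatter) from compound 1 to compound 2 and a 1.4-fold higher number (0.14 log units; within the scatter) from compound 3 to compound 4, 3.2-fold (0.51 log units) apart, beyond the scatter of two such steps. Amino in place of nitro also depended on the core, giving a 1.8-fold lower number from compound 2 to compound 4 (0.25 log units; within the scatter) without the methoxy group, while the two changes together gave a 4.1-fold lower number from compound 1 to compound 4 (0.61 log units; beyond the scatter): the same change on two cores in this assay, a 5.7-fold lower number (0.75 log units; beyond the scatter) from compound 1 to compound 3 and a 1.8-fold lower number (0.25 log units; within the scatter) from compound 2 to compound 4, 3.2-fold (0.51 log units) apart, beyond the scatter of two such steps. This shows that neither step can simply be transferred among these four compounds, but with only one pair on each side, it does not show why or whether this holds on other cores.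

The compounds shown leave open how a hydroxyl group or an acetamide would compare with the amino group, and how an ethoxy group or a chlorine atom would compare with the methoxy group. Going by these compounds, the phenoxy group is the same in all four compounds, so the effect of a benzyloxy group or an amine in its place also remains open.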